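Chloro for hydroxy on the butynyl chain of compound 2

A few compounds are considered here, and "the series" means these few. Any claim that something is new, unique, unknown or untested is made for them only; others in the source may bear on it.

Measured so far:
compound 1, `C#CCSc1cnc2ccccc2c1[Se]CC#CCCl`, 1.8 ug/mL
compound 2, `CSc1cnc2ccccc2c1[Se]CC#CCO`, 0.5 ug/mL
compound 3, `CSc1cnc2ccccc2c1[Se]CC#CCOC(=O)c1ccccc1`, 1.9 ug/mL

In a functional assay on CCRF-CEM cells (Homo sapiens) for antiproliferative activity, with a stated time of 72 h (a higher number here means a weaker inhibitor, a lower number a stronger inhibitor), compound 2 gives 0.5 ug/mL, the lowest of the three numbers; compound 1 gives 1.8 ug/mL and compound 3 gives 1.9 ug/mL, both beyond the scatter from compound 2. The unmeasured compound 4 is `CSc1cnc2ccccc2c1[Se]CC#CCCl`. Its difference from compound 2 is chloro in place of hydroxy on a saturated chain carbon bound to a triple-bonded carbon. Among the compounds with values here, the one measured step that bears on changing this hydroxy group is a 3.8-fold higher number from compound 2 to compound 3 (0.58 log units; beyond the scatter), where the hydroxyl hydrogen was replaced and the number rose modestly. Within the data shown here, no step for a chloro in place of a hydroxy is measured; compound 1, which also carries the chloro, differs from compound 4 in a second place as well, so its value only hints. Compound 4 is therefore expected to show a 2.4-fold higher number from compound 2 to compound 4 (0.38 log units; beyond the scatter), a modest rise in this assay, because compound 1 with the chloro group gives 1.8 ug/mL. The estimate for compound 4 is 1.2 ug/mL, within 0.5 ug/mL to 3 ug/mL.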

Compound 4, concentration for 50% inhibition: 1.7 ug/mL
Compound 4: middle estimate off by 1.4-fold (0.15 log units), on the low side, and the stated range covers the measured number.
By their numbers in this assay, from the lowest: compound 2; then compounds 4, 1 and 3 (each within the scatter of the next).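

In this assay, chloro in place of hydroxy on a saturated chain carbon bound to a triple-bonded carbon gives a 3.4-fold higher number from compound 2 to compound 4 (0.53 log units; beyond the scatter), so a second change at this position, after a 3.8-fold higher number from compound 2 to compound 3 (0.58 log units; beyond the scatter), also raises the number beyond the scatter. With the chloro in place, hydrogen in place of ethynyl on a saturated chain carbon bound to a sulfur gives a 1.1-fold lower number from compound 1 to compound 4 (0.02 log units; within the scatter), so that change at the other chain shows no readable effect here. Nothing presented here accounts for the step from hydroxy to chloro.

Still open, from the compounds shown here alone, is whether an amine, a methoxy group or a fluoro group at this position would stay close to compound 2 or fall with compound 4. Going by these compounds, it is also open whether the ethynyl change would remain within the scatter with the hydroxy group in place of the chloro.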